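The source may report more compounds than this note shows. Statements on the series, on what has been measured and on what is new or still open speak of the compounds shown alone.

Compound 3 `CN(C)CCNc1ccnc2cc(F)ccc12` gives 2500 nM in a functional assay on MDA-MB-231 cells (Homo sapiens) for cytotoxicity, read by sulforhodamine B assay, with a stated time of 48 h, in the presence of a further agent that is not named here (a higher number here means a weaker inhibitor of growth, a lower number a stronger inhibitor of growth), the lowest of the three numbers seen so far. Compound 1 `CCCCNc1ccnc2cc(F)ccc12` gives 7250 nM in this assay, and compound 2 `CN(C)CCNc1ccnc2cc(Cl)ccc12` gives 5660 nM. Both steps into compound 3 are modest: a 2.9-fold lower number from compound 1 to compound 3 (0.46 log units; beyond the scatter), and a 2.3-fold lower number from compound 2 to compound 3 (0.35 log units; beyond the scatter). Compound 4 `COc1ccc2c(NCCN(C)C)ccnc2c1` differs from compound 3 in one place: methoxy in place of fluoro on an aromatic carbon. For the measured compounds named here, only the step from compound 2 to compound 3 touches the same aromatic carbon, and there one halogen replaced another with a modest shift. Going by the values given here, no measured pair puts a methoxy group in place of a halogen, so that step bears on the change only indirectly, and the direction of the new step is open. A step of roughly that modest size, in either direction, is therefore expected in this assay for compound 4, and nothing larger. The estimate for compound 4 in this assay is 3200 nM, with a range from 1100 nM to 9500 nM. That estimate amounts to an expected step of a 1.3-fold higher number from compound 3 to compound 4 (0.11 log units; within the scatter).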

Compound 4, concentration for 50% growth inhibition: 4490 nM
Beside the measured number, compound 4's estimate is 1.4-fold (0.15 log units) below it, and the stated range covers the measured number.
By their numbers in this assay, from the lowest: compounds 3, 4, 2 and 1 (each within the scatter of the next, the first and the last beyond it).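

At this aromatic carbon in this assay, methoxy in place of fluoro gives a 1.8-fold higher number from compound 3 to compound 4 (0.25 log units; within the scatter) and methoxy in place of chloro gives a 1.3-fold lower number from compound 2 to compound 4 (0.10 log units; within the scatter) in the same series, so the larger group, which brings a hydrogen-bond acceptor, moves the number beyond the scatter in neither comparison. For the compounds shown here, the only step at this carbon that lies beyond the scatter is still the exchange of one halogen for the other, a 2.3-fold lower number from compound 2 to compound 3 (0.35 log units; beyond the scatter) for the same side chain. No measurement shown here explains these steps. The compounds shown leave open whether a nitrile, a trifluoromethyl group or an amine at this carbon would stay as close to compound 3 as the methoxy group does. They also leave open whether methoxy would give a similar step on the side chain of compound 1.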